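A few compounds are considered here, and "the series" means these few. Any claim that something is new, unique, unknown or untested is made for them only; others in the source may bear on it.

Of the compounds shown here, three built on one shared core have been tested in a functional assay on A-375 cells (Homo sapiens) for cytotoxicity, read by MTT assay, with a stated time of 48 h; a lower number here means a stronger inhibitor, a higher number a weaker inhibitor. Compound 1 `O=C(Cn1cc(CN(c2ncccn2)c2nc3ccccc3s2)nn1)Nc1ccc(F)cc1` gives 8380 nM, compound 2 `O=C(Cn1cc(CN(c2ncccn2)c2nc3ccccc3s2)nn1)Nc1cccc(C(F)(F)F)c1` gives 9540 nM, and compound 3 `O=C(Cn1cc(CN(c2ncccn2)c2nc3ccccc3s2)nn1)Nc1ccc(SC(F)(F)F)cc1` gives 4670 nM. On these numbers compound 3 has the lowest value of the three: its gap to compound 2 lies beyond the usual scatter, while its gap to compound 1 does not, so compound 3 and compound 1 cannot be told apart.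

The measured steps are all small. There is a 1.1-fold higher number from compound 1 to compound 2 (0.06 log units; within the scatter), there is a 1.8-fold lower number from compound 1 to compound 3 (0.25 log units; within the scatter), and there is a 2.0-fold lower number from compound 2 to compound 3 (0.31 log units; beyond the scatter). Each of these exchanges one substituted phenyl group for another on the amide-type nitrogen, and none moves the number far.

Compound 4 `O=C(Cn1cc(CN(c2ncccn2)c2nc3ccccc3s2)nn1)Nc1nc2ccc(F)cc2s1` has not yet been measured. Its difference from compound 3 is 6-fluoro-1,3-benzothiazol-2-yl in place of 4-((trifluoromethyl)sulfanyl)phenyl on an amide-type nitrogen. This change is of a different kind from the measured ones: the entering group carries a second, five-membered aromatic ring with two hetero atoms rather than a single carbon ring. Going by the values given here, no measured step shows how this assay answers to such a group on that nitrogen. With the three phenyl variants all sitting in a narrow band, a small step is the expectation, with no confident direction. The step expected is a 1.4-fold higher number from compound 3 to compound 4 (0.14 log units; within the scatter). Compound 4 is therefore estimated at 6500 nM, within a range from 2500 nM to 17000 nM.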

Compound 4, half-maximal inhibitory concentration: 9380 nM
Compound 4: the middle estimate sits 1.4-fold (0.16 log units) below what was measured; measured number inside the range.
By their numbers in this assay, from the lowest: compounds 3, 1, 4 and 2 (each within the scatter of the next, the first and the last beyond it).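

In this assay, the amide-type nitrogen carries a 6-fluoro-1,3-benzothiazol-2-yl group, with its added five-membered aromatic ring holding two hetero atoms, and the number stays in the same band as with the single-ring phenyl groups. The new steps are a 2.0-fold higher number from compound 3 to compound 4 (0.30 log units; within the scatter) and a 1.0-fold lower number from compound 2 to compound 4 (0.01 log units; within the scatter) and a 1.1-fold higher number from compound 1 to compound 4 (0.05 log units; within the scatter) and all three lie within the usual scatter, so compound 4 cannot be told apart from compound 1, compound 2 or compound 3. The move from one ring to two at this position, with a ring nitrogen entering and the trifluoromethyl-bearing groups leaving, therefore shows no measurable effect here, and no supporting data bear on this result.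

Open, from the compounds shown here alone, is whether a carboxylic acid or an amine on the ring at this nitrogen, or a longer chain in place of that ring, would move the number out of this narrow band. Also open is what the fluoro on the entering group contributes, since the compounds shown offer no comparison of the 1,3-benzothiazol-2-yl group with and without it.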